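The source may report more compounds than this note shows. Statements on the series, on what has been measured and on what is new or still open speak of the compounds shown alone.

Measured in a functional assay on U-251 cells (Homo sapiens) for antiproliferative activity, read by MTT assay, with a stated time of 48 h; on this read-out lower numbers stand for stronger inhibition and higher numbers for weaker inhibition:
- compound 1 `COc1cc(-c2cccc3nc(-c4cccc(Br)c4)oc23)cc(OC)c1OC`: 6800 nM
- compound 2 `COc1cc(-c2nc3cccc(-c4cc(OC)c(OC)c(OC)c4)c3o2)ccc1O`: 10300 nM

Not yet measured:
- compound 3 `COc1cc(-c2cccc3nc(-c4cccc(N)c4)oc23)cc(OC)c1OC`

Among the compounds with values here, only two numbers are available in this assay, and compound 2 stands level with compound 1 once the usual scatter is allowed for, so the two cannot be ranked. Compound 3 keeps the shared core and differs from compound 2 at one place, on an aromatic carbon of a five-membered aromatic ring with 1 nitrogen and 1 oxygen: 3-aminophenyl in place of 4-hydroxy-3-methoxyphenyl (3-aminophenyl in place of 4-hydroxy-3-methoxyphenyl on an aromatic carbon). Within the data shown here, the single measured step at this place is a 1.5-fold higher number from compound 1 to compound 2 (0.18 log units; within the scatter), an exchange of 3-bromophenyl for 4-hydroxy-3-methoxyphenyl. Among the measured compounds shown here, no measured compound carries 3-aminophenyl, so this one step is the only guide, and it is a thin one. It gives no reason to expect a large change in either direction. The expected change is therefore none beyond the scatter, and the estimated step is a 1.4-fold lower number from compound 2 to compound 3 (0.14 log units; within the scatter). For compound 3 the estimated value is 7500 nM, with an expected range from 2500 nM to 20000 nM.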

Compound 3, half-maximal inhibitory concentration: 2200 nM
For compound 3 the middle estimate is 3.4-fold (0.53 log units) above the measured one, outside the stated range (below it).
By their numbers in this assay, from the lowest: compound 3; then compounds 1 and 2 (each within the scatter of the next).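

In this assay, within the data shown here, the group on an aromatic carbon of the five-membered aromatic ring with 1 nitrogen and 1 oxygen now proves able to shift the read-out: exchanging 4-hydroxy-3-methoxyphenyl for 3-aminophenyl gives a 4.7-fold lower number from compound 2 to compound 3 (0.67 log units; beyond the scatter), whereas the only earlier exchange at this place stayed within the scatter. The cleaner comparison is amino in place of bromo on the phenyl group, which gives a 3.1-fold lower number from compound 1 to compound 3 (0.49 log units; beyond the scatter), so one substituent on that ring is enough to set compound 3 apart from compound 1. Among these three compounds, only the one carrying 3-aminophenyl stands apart, and no measurement shown here bears on what lies behind this difference.

As far as these compounds go, it remains open whether the lower number depends on the free amine or would persist with a dimethylamino group, an acetamide or a hydroxyl in its place. Among these compounds, with only three compounds from a single cell line, it is also open whether the amino exchange would give a similar step on a different core or in other cells.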